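Working notes: carbamate in place of the amide-propyl chain

The compounds below may be only part of what the source reports. "The series", "measured", "known", "first", "only" and "open" are said of these compounds alone.

Three analogues of one shared core have been measured in a functional assay on PANC-1 cells (Homo sapiens) for inhibition, read by MTT assay, with a stated time of 24 h, tested at 10 uM; on this read-out higher numbers stand for more inhibition at the one concentration tested (going by the name of the read-out) and lower numbers for less inhibition. Compound 1 `CC(C)=CCC/C(C)=C/CC1Cc2c(OCCCNS(=O)(=O)c3ccc([N+](=O)[O-])cc3)cc(=O)n(CCCO)c2CC1(C)C` gives 0%, compound 2 `COc1ccc(C(=O)NCCCOc2cc(=O)n(CCCO)c3c2CC(C/C=C(\C)CCC=C(C)C)C(C)(C)C3)cc1` gives 14.1%, and compound 3 `CC(C)=CCC/C(C)=C/CC1Cc2c(OCCCNC(=O)c3ccco3)cc(=O)n(CCCO)c2CC1(C)C` gives 2.8%. Compound 3 is the second highest of the three numbers: its nearest neighbour is compound 1, lower but within the scatter, and the only separation beyond the scatter is to compound 2, as a number 11.3 percentage points lower from compound 2 to compound 3 (beyond the scatter) shows. The measured steps all sit on the amine nitrogen at the end of the propyl linker: a number 14.1 percentage points higher from compound 1 to compound 2 (beyond the scatter) is modest, and a number 2.8 percentage points higher from compound 1 to compound 3 (within the scatter) stays within the scatter.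

Compound 4 `CC(C)=CCC/C(C)=C/CC1Cc2c(OC(=O)Nc3ccc(F)cc3)cc(=O)n(CCCO)c2CC1(C)C` is built differently: (4-fluorophenyl)carbamoyl in place of 3-(((furan-2-yl)carbonyl)amino)propyl on an oxygen on an aromatic ring. The propyl linker and its amide are gone, and the oxygen on the aromatic ring now carries the (4-fluorophenyl)carbamoyl group directly. Within the data shown here, none of the three measured steps touches this oxygen or removes the linker, so no step bears directly on the change. What the series does show is that every measured number is low and that changes at the chain end moved the read-out only modestly. Compound 4 is therefore expected to remain low, with a number 5.2 percentage points higher from compound 3 to compound 4 (within the scatter) estimated as a step not clearly beyond the scatter. For compound 4 the estimated value is 8%, with a range from 0% to 25%.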

Compound 4, a percentage reported as inhibition, at one concentration (the size of the read-out at that concentration, not a potency): 6.2%
Compound 4: middle estimate off by 1.8 percentage points, on the high side; the range from low to high includes it.
By their numbers in this assay, from the lowest: compounds 1, 3, 4 and 2 (each within the scatter of the next, the first and the last beyond it).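

Among these compounds, exchanging 3-(((furan-2-yl)carbonyl)amino)propyl for (4-fluorophenyl)carbamoyl on an oxygen on an aromatic ring gives a number 3.4 percentage points higher from compound 3 to compound 4 (within the scatter) in this assay, a reading at this oxygen, whereas the earlier steps changed only the group on the amine nitrogen at the chain end. For this pair, losing the propyl linker and its amide while placing the carbamoyl group directly on the oxygen does not move the read-out beyond the scatter, and it gives no sign of a gain at this position. No available evidence accounts for this result.

This single step changes the linker, the amide and the aromatic ring together, so the compounds shown do not separate the contribution of each part. Also open, from the compounds shown here alone, is how the carbamate on this oxygen reads when the 4-fluorophenyl is replaced by an unsubstituted phenyl or a furan-2-yl group, or when a longer chain ending in a dimethylamino group or a carboxylic acid is attached to the carbamate nitrogen.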